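Extending the Acyl Chain on a Weak Cytotoxic Amide

A few compounds are considered here, and "the series" means these few. Any claim that something is new, unique, unknown or untested is made for them only; others in the source may bear on it.

Compound 2 `CCCC(=O)N1c2ccccc2CCC1C(=O)Nc1cc(C(F)(F)F)cc(C(F)(F)F)c1` stands, among the three compounds measured in a functional assay on HCT-15 cells (Homo sapiens) for cytotoxicity, read by sulforhodamine B assay, with a stated time of 72 h (a higher number here means a weaker inhibitor of growth, a lower number a stronger inhibitor of growth), at the highest number: compound 2 gives 21900 nM. Among the compounds with values here, its nearest neighbour is compound 1 `O=C(Nc1cc(C(F)(F)F)cc(C(F)(F)F)c1)C1CCc2ccccc2N1C(=O)c1ccccc1Cl`, which in this assay gives 4050 nM; the step of a 5.4-fold higher number from compound 1 to compound 2 (0.73 log units; beyond the scatter) is the only single-point change measured so far. Furthest away stands compound 3 `O=C(Nc1ccccc1C(F)(F)F)C1CCc2ccccc2N1C(=O)c1cccc(Cl)c1`, which in this assay gives 797 nM; compound 3 differs from compound 2 in more than one place, so the two values can only be set side by side.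

Compound 4 `CCCCCCCCC(=O)N1c2ccccc2CCC1C(=O)Nc1cc(C(F)(F)F)cc(C(F)(F)F)c1` differs from compound 2 by pentyl in place of hydrogen on a saturated chain carbon, three bonds along the chain from a carbonyl carbon. Within the data shown here, no measured pair shows this change or one resembling it: the only recorded step, a 5.4-fold higher number from compound 1 to compound 2 (0.73 log units; beyond the scatter), exchanges an aryl group for a short chain and says nothing about lengthening a chain that is already present. The expectation for compound 4 in this assay therefore rests on the absence of evidence in either direction, and a change not clearly beyond the scatter is expected, a 1.5-fold lower number from compound 2 to compound 4 (0.16 log units; within the scatter). Compound 4 is estimated at 15000 nM, with a range from 4000 nM to 60000 nM.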

Compound 4, concentration for 50% growth inhibition: 4970 nM
Compound 4: middle estimate off by 3.0-fold (0.48 log units), on the high side; measured number inside the range.
By their numbers in this assay, from the lowest: compound 3; then compounds 1 and 4 (each within the scatter of the next); then compound 2.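

In this assay, within the data shown here, the acyl chain proves to be a place where length matters, since pentyl in place of hydrogen, three bonds along the chain from a carbonyl carbon, gives a 4.4-fold lower number from compound 2 to compound 4 (0.64 log units; beyond the scatter) and so moves the number beyond the scatter, something no earlier pair could show. The octyl chain also stands level with the aryl group it replaces, with a 1.2-fold higher number from compound 1 to compound 4 (0.09 log units; within the scatter) as the step, so the loss seen on going from 2-chlorophenyl to propyl does not hold for every chain in this place. Nothing measured here explains why the octyl chain of compound 4 gives a lower number than the propyl chain of compound 2.

From the compounds shown here alone, with only propyl and octyl in hand, it remains open whether the number falls steadily with length or changes abruptly at some intermediate chain, and whether a longer chain such as dodecyl, or a chain ending in an amine or a carboxylic acid, would hold the same level. Compound 3 differs from compound 4 in more than one place, so that pair cannot be read as the effect of any single change.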